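Changing the aromatic ring on the amide of compound 1

The compounds below may be only part of what the source reports. "The series", "measured", "known", "first", "only" and "open" are said of these compounds alone.

Three measured compounds share one core and differ only in the aromatic ring attached to the amide carbonyl. Compound 1 `O=C(NC1CCN(Cc2ccc(OC3CCNCC3)c(Br)c2)CC1)c1ccccn1` carries pyridin-2-yl there, and in an assay on HEK293 cells for displacement of a labelled ligand from Urotensin-2 receptor (Homo sapiens), read by fluorescence, with a stated time of 90 min (on this read-out lower numbers stand for stronger inhibition and higher numbers for weaker inhibition), compound 1 gives 120 nM, the highest of the three numbers. Compound 2 `O=C(NC1CCN(Cc2ccc(OC3CCNCC3)c(Br)c2)CC1)c1cc2cc(Cl)ccc2s1` has 5-chloro-1-benzothiophen-2-yl in that place and gives 51 nM; compound 3 `N#Cc1ccc2cc(C(=O)NC3CCN(Cc4ccc(OC5CCNCC5)c(Br)c4)CC3)sc2c1` has 6-cyano-1-benzothiophen-2-yl and gives 80 nM. The step of a 2.4-fold lower number from compound 1 to compound 2 (0.37 log units; beyond the scatter) is modest but beyond the scatter, whereas a 1.5-fold lower number from compound 1 to compound 3 (0.18 log units; within the scatter) and a 1.6-fold higher number from compound 2 to compound 3 (0.20 log units; within the scatter) both stay within it.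

Compound 4 `Cc1ccc2sc(C(=O)NC3CCN(Cc4ccc(OC5CCNCC5)c(Br)c4)CC3)cc2c1` is the next member of the set: 5-methyl-1-benzothiophen-2-yl in place of pyridin-2-yl on a carbonyl carbon. The two measured steps that exchange pyridin-2-yl for a benzothiophene bear on it directly; both lower the number, one clearly and one only within the scatter. From the compounds shown here alone, a methyl on the benzothiophene has not been tested, so its own contribution is unknown from these data. A small lowering is therefore expected, a 1.8-fold lower number from compound 1 to compound 4 (0.27 log units; within the scatter). Compound 4 is expected to give about 65 nM, with a plausible range from 30 nM to 140 nM.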

Compound 4, half-maximal inhibitory concentration: 74 nM
For compound 4 the middle estimate is 1.1-fold (0.06 log units) below the measured one, within the range that was stated.
By their numbers in this assay, from the lowest: compounds 2, 4, 3 and 1 (each within the scatter of the next, the first and the last beyond it).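

In this assay, the step to the 5-methyl-1-benzothiophen-2-yl group is small: a 1.6-fold lower number from compound 1 to compound 4 (0.21 log units; within the scatter), so exchanging pyridin-2-yl for a benzothiophene does not in itself give a change beyond the scatter, and of the three benzothiophenes only compound 2 stands clearly apart from compound 1. Changing what the benzothiophene carries also has little effect on the number, with a 1.5-fold higher number from compound 2 to compound 4 (0.16 log units; within the scatter) for methyl in place of chloro and a 1.1-fold lower number from compound 3 to compound 4 (0.03 log units; within the scatter) for the exchange of the 6-cyano compound for the 5-methyl compound, so compounds 2, 3 and 4 cannot be ranked against one another. No measurement is available that would explain these numbers.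

The compounds shown leave open how a benzothiophene with no added group would read at this place on the carbonyl carbon, so the separate contribution of methyl, chloro or cyano remains unknown. They also leave open whether an amine or a carboxylic acid on the benzothiophene would keep the number in this range or move it well beyond the scatter.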